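This account rests on a few compounds, and the source may have more. Where it says the series, first, only, none or still open, it means among the compounds named here.

Of the compounds shown here, two built on a shared core have so far been measured in a functional assay on LM7 cells (Homo sapiens) for antiproliferative activity, read by MTT assay, with a stated time of 72 h; a higher number here means a weaker inhibitor, a lower number a stronger inhibitor. Compound 1 `Cc1ccc2c(=O)c(CSC(=S)N3CCCCC3)coc2c1` bears piperidin-1-yl on the thiocarbonyl carbon, and in this assay compound 1 gives 5100 nM. Compound 2 `Cc1ccc2c(=O)c(CSC(=S)N3CCCC3)coc2c1` bears pyrrolidin-1-yl in that place, and in this assay compound 2 gives 3400 nM. Among the compounds with values here, the single measured step, a 1.5-fold lower number from compound 1 to compound 2 (0.18 log units; within the scatter), lies within the scatter, so compound 2 stands level with compound 1 rather than apart from it. Compound 3 `Cc1ccc2c(=O)c(CSC(=S)N(C(C)C)C(C)C)coc2c1` has not yet been measured; it differs from compound 2 by diisopropylamino in place of pyrrolidin-1-yl on a thiocarbonyl carbon. Within the data shown here, the only step that bears on this change is a 1.5-fold lower number from compound 1 to compound 2 (0.18 log units; within the scatter), which likewise exchanged the amine on the thiocarbonyl carbon and left the number essentially where it was. Nothing in the data points to either direction, so the expected step in this assay is a 1.1-fold higher number from compound 2 to compound 3 (0.02 log units; within the scatter), which amounts to no change beyond the scatter. Compound 3 is therefore estimated to give 3600 nM in this assay, with a plausible range from 1500 nM to 9000 nM.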

Compound 3, half-maximal inhibitory concentration: 6300 nM
Compound 3: middle estimate off by 1.8-fold (0.24 log units), on the low side; low and high end bracket the measured number.
By their numbers in this assay, from the lowest: compounds 2, 1 and 3 (each within the scatter of the next).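

In this assay, the position on the thiocarbonyl carbon now accepts an amine with no ring: the exchange for diisopropylamino gives a 1.9-fold higher number from compound 2 to compound 3 (0.27 log units; within the scatter) when pyrrolidin-1-yl leaves and a 1.2-fold higher number from compound 1 to compound 3 (0.09 log units; within the scatter) when piperidin-1-yl leaves. Within the data shown here, the earlier pair had compared only two ring amines, whereas these steps show that an open amine with two branched chains also stays level with both of them, so neither the presence of a ring nor the change from pyrrolidin-1-yl to piperidin-1-yl separates the three compounds beyond the scatter. No measurement is at hand that could explain why these three amines stand level.

From the compounds shown here alone, it remains open whether this level holds for amines of another kind at the same place, such as the smaller dimethylamino, a morpholine ring with its added oxygen, or a piperazine ring with its second nitrogen. Also open, going by these compounds, is whether any change away from this place, such as an oxygen in place of the thiocarbonyl sulfur or a different group in place of the methyl on the shared core, would move the number beyond the scatter.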